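A few compounds are considered here, and "the series" means these few. Any claim that something is new, unique, unknown or untested is made for them only; others in the source may bear on it.

Measured so far:
- compound 1 `CC(C)S(=O)(=O)c1ccc(Cl)c(C#Cc2cc(Cl)ccc2OCC(=O)O)c1` gives 11.7 mL/min/kg as its clearance
- compound 2 `CC(C)c1ccc(S(C)(=O)=O)cc1C#Cc1cc(Cl)ccc1OCC(=O)O` gives 8.33 mL/min/kg as its clearance

Both numbers come from an in vivo ADME assay on the whole organism (strain BALB/c) for pharmacokinetics, with Mus musculus as the target, read by LC-MS, at a dose of 5 mg/kg by the oral route (on this read-out lower numbers stand for slow clearance and higher numbers for fast clearance), and they are the only ones available so far. Compound 2 at 8.33 mL/min/kg lies within the usual scatter of compound 1 at 11.7 mL/min/kg and so cannot be told apart from it.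

The next compound to be read is compound 3 `CS(=O)(=O)c1ccc(Cl)c(C#Cc2cc(Cl)ccc2OCC(=O)O)c1` which differs from compound 2 in one place. The change chloro in place of isopropyl on an aromatic carbon puts chloro in place of isopropyl on an aromatic carbon, ortho to a large group and para to a methylsulfonyl group.

Among the measured compounds shown here, no pair of measured compounds shows the size of a change like this one in this assay and the two values give no direction to follow, so no shift beyond the scatter is expected. The expected step of a 1.2-fold higher number from compound 2 to compound 3 (0.08 log units; within the scatter) is an estimate that stays within that scatter. For compound 3 the estimated clearance is 10 mL/min/kg with an expected range from 5 mL/min/kg to 20 mL/min/kg for the coming measurement.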

Compound 3, clearance: 11.7 mL/min/kg
The estimate for compound 3 lay 1.2-fold (0.07 log units) below the measured number; the measured number falls inside the stated range.
By their numbers in this assay, from the lowest: compounds 2, 1 and 3 (each within the scatter of the next).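

In this assay, putting chloro in place of isopropyl on an aromatic carbon, ortho to a large group and para to a methylsulfonyl group, gives a 1.4-fold higher number from compound 2 to compound 3 (0.15 log units; within the scatter) and so leaves the clearance indistinguishable from that of the isopropyl compound. Among the compounds shown here, this is the first one-place reading at this position, and it shows that a swap from three heavy atoms to one can be made here without a step beyond the scatter. The second one-place comparison, methyl in place of isopropyl on a sulfonyl sulfur, gives no change at the digits printed from compound 1 to compound 3 (within the scatter) and so shows that these two groups on the sulfur cannot be told apart on this read-out either, while no supporting data are available to explain either reading.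

As far as these compounds go, it remains open whether a nitrile, a trifluoromethyl or an amine on that aromatic carbon would produce a step beyond the scatter. It is equally open whether a longer chain or a cyclopropyl group on the sulfonyl sulfur would do so, since only methyl and isopropyl are shown there.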